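The source may report more compounds than this note shows. Statements on the series, on what has been measured and on what is new or still open speak of the compounds shown alone.

Measured in a functional assay on A549 cells (Homo sapiens) for inhibition, read by sulforhodamine B assay, with a stated time of 72 h; a lower number here means a stronger inhibitor, a higher number a weaker inhibitor:

- compound 1 `COc1cc2c(Nc3ccc(F)c(Cl)c3)ncnc2cc1OCCCCCCn1ccnc1[N+](=O)[O-]`: 13400 nM
- compound 2 `COc1cc2c(Nc3ccc(F)c(Cl)c3)ncnc2cc1OCCOCCn1ccnc1[N+](=O)[O-]`: 12900 nM
- compound 3 `C#Cc1cccc(Nc2ncnc3cc(OCCOCCn4ccnc4[N+](=O)[O-])c(OC)cc23)c1`: 9770 nM

These three compounds share a core and differ only in the chain or in the group on the nitrogen. Compound 2, at 12900 nM, cannot be told apart from either measured neighbour: a 1.0-fold lower number from compound 1 to compound 2 (0.02 log units; within the scatter), and a 1.3-fold lower number from compound 2 to compound 3 (0.12 log units; within the scatter).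

The next compound is compound 4 `COc1cc2c(Nc3ccc(OCc4cccc(F)c4)c(Cl)c3)ncnc2cc1OCCOCCn1ccnc1[N+](=O)[O-]`. It has (3-fluorobenzyl)oxy in place of fluoro on an aromatic carbon, ortho to a chloro group: (3-fluorobenzyl)oxy in place of fluoro on an aromatic carbon.

The closest guide is a 1.3-fold lower number from compound 2 to compound 3 (0.12 log units; within the scatter), since that change also alters the aromatic group on the nitrogen. The chain change, a 1.0-fold lower number from compound 1 to compound 2 (0.02 log units; within the scatter), lies elsewhere in the molecule and bears on this question only indirectly. Neither step tests a group as large as the one entering here, so the data leave real uncertainty. Among the compounds with values here, with both steps within the scatter, the default expectation is a small change, with no step clearly beyond the scatter and a slight lean towards a lower number. The expected step is a 1.6-fold lower number from compound 2 to compound 4 (0.21 log units; within the scatter).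

The estimated value for compound 4 is 8000 nM, with an expected range from 2500 nM to 18000 nM.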

Compound 4, half-maximal inhibitory concentration: 5060 nM
Estimate against measurement, compound 4: 1.6-fold (0.20 log units) above, and the stated range covers the measured number.
By their numbers in this assay, from the lowest: compounds 4, 3, 2 and 1 (each within the scatter of the next, the first and the last beyond it).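

In this assay, replacing fluoro with (3-fluorobenzyl)oxy gives a 2.5-fold lower number from compound 2 to compound 4 (0.41 log units; beyond the scatter), and this modest step is the first in the series shown to pass beyond the scatter; neither the chain change nor the swap of the aromatic group on the nitrogen did so. It shows that this position, on an aromatic carbon ortho to a chloro group, tolerates a far larger group, with 9 heavy atoms and a six-membered aromatic ring entering where 1 heavy atom leaves, and that the number falls rather than rises. No measurement shown here accounts for this fall.

The compounds shown leave open which part of the entering group matters: an unsubstituted benzyloxy group, a simple methoxy group or a 3-chlorobenzyl ether at the same position would help separate the roles of the oxygen link, the ring and the fluorine on it. From the compounds shown here alone, it also remains open whether (3-fluorobenzyl)oxy would give a similar step when paired with the all-carbon chain of compound 1.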